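The compounds below may be only part of what the source reports. "The series", "measured", "known", "first", "only" and "open" are said of these compounds alone.

Measured so far:
- compound 1 `COc1cc(/C=N/NC(=O)c2cnccn2)ccc1O` — 47%
- compound 2 `O=C(N/N=C/c1ccc(-c2ccccc2)cc1)c1cnccn1` — 57.3%
- compound 3 `O=C(N/N=C/c1ccc(O)cc1)c1cnccn1` — 61.4%

In a functional assay on the whole organism (Abdomen, strain Swiss) for inhibition, with Mus musculus as the target, with stated times of 40 min and 25 min, at a dose of 100 umol/kg by the oral route (a higher number here means more inhibition at the dose given (going by the name of the read-out), a lower number less inhibition), compound 1 stands lowest of the three, with compound 2 and compound 3 both above it beyond the usual scatter. Compound 4 `COc1ccc(/C=N/NC(=O)c2cnccn2)cc1OC` is not yet measured; it differs from compound 1 by methyl in place of hydrogen on an oxygen on an aromatic ring. The two measured steps touch the same aromatic ring but not this change: a number 14.4 percentage points higher from compound 1 to compound 3 (beyond the scatter) and a number 4.1 percentage points higher from compound 2 to compound 3 (within the scatter). Neither replaces a hydrogen on an oxygen with a methyl, so they give no direct guide. Among the compounds with values here, with no comparable step in hand, the estimate for compound 4 is a step of a number 4 percentage points lower from compound 1 to compound 4 (within the scatter), within the scatter, and its expected read-out is 43%, with a range from 25% to 60%.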

Compound 4, a percentage reported as inhibition, in the whole organism at one dose (the size of the read-out at that dose, not a potency): 73.6%
Estimate against measurement, compound 4: 30.6 percentage points below; the measured number lies above the stated range.
By their numbers in this assay, from the lowest: compound 1; then compounds 2 and 3 (each within the scatter of the next); then compound 4.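

In this assay, turning the hydroxy into a methoxy on this aromatic ring gives a number 26.6 percentage points higher from compound 1 to compound 4 (beyond the scatter). Within the data shown here, this is the first step that changes this oxygen, and it shows that the hydrogen on it is not required for inhibition at this dose, since replacing it with methyl does not lower the number. Nothing available here explains the size of this rise.

The compounds shown leave open whether a longer chain on this oxygen, such as ethyl, would hold this level. They also leave open what an amine in place of the methoxy would do.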